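A Cyclohexyl Urea Variant on the Shared Core

A few compounds are considered here, and "the series" means these few. Any claim that something is new, unique, unknown or untested is made for them only; others in the source may bear on it.

In a functional assay on SMMC-7721 cells (Homo sapiens) for cytotoxicity, read by MTT assay, with a stated time of 72 h (on this read-out higher numbers stand for weaker inhibition and lower numbers for stronger inhibition), compound 3 `CCN(C)C(=O)N1CCN(C(=S)SCc2cn(Cc3ccc(F)cc3)nn2)CC1` gives 23700 nM, the lowest number shown so far, though compound 2 `CCNC(=O)N1CCN(C(=S)SCc2cn(Cc3ccc(F)cc3)nn2)CC1` gives 44400 nM and the gap a 1.9-fold lower number from compound 2 to compound 3 (0.27 log units; within the scatter) lies within the scatter. Compound 1 `NC(=O)N1CCN(C(=S)SCc2cn(Cc3ccc(F)cc3)nn2)CC1` reaches only a limit, > 128000 nM, in this assay. Compound 4 `O=C(NC1CCCCC1)N1CCN(C(=S)SCc2cn(Cc3ccc(F)cc3)nn2)CC1` differs from compound 3 by cyclohexylamino in place of ethyl(methyl)amino on a carbonyl carbon. The measured steps that bear on this change are an at least 2.8-fold lower number from compound 1 to compound 2 (0.45 log units; beyond the scatter) and an at least 5.4-fold lower number from compound 1 to compound 3 (0.73 log units; beyond the scatter), both adding carbon to the urea nitrogen, and a 1.9-fold lower number from compound 2 to compound 3 (0.27 log units; within the scatter). Cyclohexylamino carries the substitution further while restoring a hydrogen-bond donor, as in compound 2. The step of a 1.6-fold lower number from compound 3 to compound 4 (0.20 log units; within the scatter) is therefore expected to be small, at most a modest lowering. Compound 4 is estimated at 15000 nM, within 4000 nM to 50000 nM.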

Compound 4, half-maximal inhibitory concentration: > 128000 nM
Compound 4: a limit, no number; the forecaster's own chance of this, stated with the estimate: 3%; middle value at least 8.5-fold (0.93 log units) away from the limit.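

Adding carbon to the urea nitrogen does not keep lowering the number: cyclohexylamino reverses the direction, with an at least 5.4-fold higher number from compound 3 to compound 4 (0.73 log units; beyond the scatter) and an at least 2.8-fold higher number from compound 2 to compound 4 (0.45 log units; beyond the scatter). The trend seen from compound 1 to compound 2 and compound 3 therefore does not extend to this six-membered ring on the carbonyl carbon. The step from compound 1 to compound 4 cannot be read, as both compounds sit at the same limit: the limit of > 128000 nM in this assay, at which 2 of the 4 values shown sit.

As far as these compounds go, whether the ring itself or its carbon count matters stays open. A straight hexyl chain, a cyclopropyl ring or a morpholine ring on the same carbonyl carbon would bear on that question.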